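This account rests on a few compounds, and the source may have more. Where it says the series, first, only, none or still open, it means among the compounds named here.

The compounds share one core and differ only in the ring attached to a saturated ring carbon of the pyrazoline. Compound 1 `O=C1NC(=O)/C(=C\c2ccc(OCC(=O)N3N=C(c4ccc(F)cc4)CC3c3ccccc3)cc2)S1` carries an unsubstituted phenyl there and in an assay on cells for inhibition of histone deacetylase 4 (Homo sapiens), read by fluorescence, with a stated time of 30 min (a higher number here means a weaker inhibitor, a lower number a stronger inhibitor), compound 1 gives 4200 nM. Compound 2 `O=C1NC(=O)/C(=C\c2ccc(OCC(=O)N3N=C(c4ccc(F)cc4)CC3c3ccccc3Cl)cc2)S1` carries a 2-chlorophenyl and in this assay compound 2 gives 1100 nM. Compound 3 `O=C1NC(=O)/C(=C\c2ccc(OCC(=O)N3N=C(c4ccc(F)cc4)CC3c3ccc(F)cc3)cc2)S1` carries a 4-fluorophenyl and in this assay compound 3 gives 1400 nM, the second highest of the three numbers; the gap from compound 2 is small, a 1.3-fold higher number from compound 2 to compound 3 (0.10 log units; within the scatter), while the gap from compound 1 is larger, a 3.0-fold lower number from compound 1 to compound 3 (0.48 log units; beyond the scatter).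

Compound 4 `Cc1ccc(C2CC(c3ccc(F)cc3)=NN2C(=O)COc2ccc(/C=C3/SC(=O)NC3=O)cc2)cc1` is the next step: methyl in place of fluoro on an aromatic carbon. Within the data shown here, no measured pair swaps methyl for fluoro, so the only guidance is that adding a halogen to the bare phenyl lowered the number modestly, a 3.8-fold lower number from compound 1 to compound 2 (0.58 log units; beyond the scatter) and a 3.0-fold lower number from compound 1 to compound 3 (0.48 log units; beyond the scatter), and that the two substituted rings sit close together. A substituent of the same small size in the same place is therefore expected to leave the number near that of compound 3, with a step no larger than the scatter, no change at the digits printed from compound 3 to compound 4 (within the scatter). The estimate for compound 4 in this assay is 1400 nM, within 600 nM to 3500 nM.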

Compound 4, half-maximal inhibitory concentration: 1800 nM
Beside the measured number, compound 4's estimate is 1.3-fold (0.11 log units) below it; measured number inside the range.
By their numbers in this assay, from the lowest: compounds 2, 3 and 4 (each within the scatter of the next); then compound 1.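

Swapping fluoro for methyl on this ring, para to a large group, is a step within the scatter in this assay (a 1.3-fold higher number from compound 3 to compound 4 (0.11 log units; within the scatter)), so at this place a small carbon group and a halogen cannot be told apart. Adding methyl to the bare phenyl still gives a step beyond the scatter (a 2.3-fold lower number from compound 1 to compound 4 (0.37 log units; beyond the scatter)), which shows that the lower number seen with chloro and fluoro is not limited to halogens among these compounds. The 4-methylphenyl and 2-chlorophenyl rings also remain within the scatter of each other (a 1.6-fold higher number from compound 2 to compound 4 (0.21 log units; within the scatter)), and no measurement on hand explains any of these steps.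

On these data alone, what stays open is whether a longer chain such as propyl keeps the number at this place. An amine or a carboxylic acid there could also shift it in either direction.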